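The source may hold more compounds than are shown below. What is called first, only, known or untested is meant among the compounds shown, and "the series" means these compounds.

Compound 1 `COc1ccccc1-c1nnc(SCCn2c([N+](=O)[O-])cnc2C)o1` gives 10000 nM in a functional assay on HepG2 cells (Homo sapiens) for cytotoxicity, read by MTT assay, with a stated time of 48 h; a higher number here means a weaker inhibitor, a lower number a stronger inhibitor. Compound 2 `COc1cc(OC)cc(-c2nnc(SCCn3c([N+](=O)[O-])cnc3C)o2)c1` gives 10500 nM in this assay.

Going by the values given here, these two numbers sit within the usual scatter of each other, so compound 1 stands alongside compound 2 rather than apart from it; both are weak inhibitors of this cell line, and no step between measured compounds is available to show what a change at the aromatic carbon of the shared core does.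

Compound 3 `Cc1ncc([N+](=O)[O-])n1CCSc1nnc(-c2cccs2)o1` has not yet been measured. It differs from compound 1 in one place: thiophen-2-yl in place of 2-methoxyphenyl on an aromatic carbon. Where it sits is on an aromatic carbon of a five-membered aromatic ring with 2 nitrogen and 1 oxygen, two ring bonds from the ring atom that bears a large group.

Among the compounds with values here, with only two measured compounds, both weak and alike, compound 3 is expected to stay in the same region, and the step of no change at the digits printed from compound 1 to compound 3 (within the scatter) is estimated to lie within the scatter. In this assay compound 3 is expected to give about 10000 nM, with a likely range from 4000 nM to 25000 nM.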

Compound 3, half-maximal inhibitory concentration: 20500 nM
Estimate against measurement, compound 3: 2.1-fold (0.31 log units) below, and the stated range covers the measured number.
By their numbers in this assay, from the lowest: compounds 1, 2 and 3 (each within the scatter of the next, the first and the last beyond it).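

Going by these compounds alone, this is the first readable step at this position: in this assay, thiophen-2-yl in place of 2-methoxyphenyl gives a 2.1-fold higher number from compound 1 to compound 3 (0.31 log units; beyond the scatter) and so moves the result towards a weaker inhibitor. The group on this aromatic carbon can therefore shift the number, which the earlier pair could not show, although the step is modest and the only one available. Nothing measured here accounts for it.

The compounds shown leave open whether an unsubstituted phenyl would separate the change of ring from the loss of the methoxy group. They also leave open whether another group at this position, such as an amine or a pyridine ring, would give a lower number than compound 1 at 10000 nM.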